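Propargylsulfanyl to methylsulfanyl on two related cores

The compounds below may be only part of what the source reports. "The series", "measured", "known", "first", "only" and "open" are said of these compounds alone.

Compound 1 `C#CCSc1cnc2ccccc2c1[Se]CC#CCCl` carries a propargylsulfanyl group; in a functional assay on B16 cells (Mus musculus) for antiproliferative activity, with a stated time of 72 h (a higher number here means a weaker inhibitor, a lower number a stronger inhibitor), compound 1 gives 7.1 ug/mL. Compound 2 `CSc1cnc2ccccc2c1[Se]CC#CCCl` differs from compound 1 by hydrogen in place of ethynyl on a saturated chain carbon bound to a sulfur, and in this assay compound 2 gives 3.5 ug/mL; the step is a 2.0-fold lower number from compound 1 to compound 2 (0.31 log units; beyond the scatter). Compound 3 `C#CCSc1cnc2ccccc2c1SCC#CCCl` keeps the propargylsulfanyl group, but its core differs from the core of compound 1 by a group of 6 heavy atoms (4 carbon, 1 sulfur, 1 chlorine; no ring) in place of a group of 6 heavy atoms (4 carbon, 1 chlorine, 1 selenium; no ring), on an aromatic carbon; in this assay compound 3 gives 52.8 ug/mL, a step of a 7.4-fold higher number from compound 1 to compound 3 (0.87 log units; beyond the scatter). Compound 3 thus has the highest number of the three measured compounds, and its steps to compound 1 and to compound 2 both lie beyond the scatter.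

Compound 4 `CSc1cnc2ccccc2c1SCC#CCCl` is not yet measured. It differs from compound 3 by hydrogen in place of ethynyl on a saturated chain carbon bound to a sulfur, which is the same change as that from compound 1 to compound 2: the place reads the same word for word, on a saturated chain carbon bound to a sulfur. Going by the values given here, the only precedent for this change is the single step of a 2.0-fold lower number from compound 1 to compound 2 (0.31 log units; beyond the scatter), made on the core of compound 1; whether it carries over unchanged to the core of compound 3 is not known from these data. For compound 4 in this assay a step of about a 2.0-fold lower number from compound 3 to compound 4 (0.31 log units; beyond the scatter) is expected, resting on a 2.0-fold lower number from compound 1 to compound 2 (0.31 log units; beyond the scatter), with a wide range to allow for the change of core. The estimated value for compound 4 in this assay is 26 ug/mL, expected to fall between 12 ug/mL and 60 ug/mL.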

Compound 4, concentration for 50% inhibition: 16.9 ug/mL
For compound 4 the middle estimate is 1.5-fold (0.19 log units) above the measured one; measured number inside the range.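

On the core of compound 3, propargyl to methyl gives in this assay a 3.1-fold lower number from compound 3 to compound 4 (0.49 log units; beyond the scatter), and this step agrees with its precedent on the core of compound 1: the same change on two cores in this assay, a 2.0-fold lower number (0.31 log units; beyond the scatter) from compound 1 to compound 2 and a 3.1-fold lower number (0.49 log units; beyond the scatter) from compound 3 to compound 4, 1.5-fold (0.19 log units) apart, within the scatter of two such steps. The change of core also holds its size when read with the methylsulfanyl group in place, where it gives a 4.8-fold higher number from compound 2 to compound 4 (0.68 log units; beyond the scatter), and it agrees with the same change read with the propargylsulfanyl group: the same change on two cores in this assay, a 7.4-fold higher number (0.87 log units; beyond the scatter) from compound 1 to compound 3 and a 4.8-fold higher number (0.68 log units; beyond the scatter) from compound 2 to compound 4, 1.5-fold (0.19 log units) apart, within the scatter of two such steps. Within these four compounds, the propargyl to methyl change therefore carries over between the two cores without a measurable change in size, but this rests on one pair of compounds per core in a single assay, and it shows neither that the agreement extends to any further core nor why the step has this direction.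

The compounds shown leave open whether a longer chain such as butyl, or an amine, in place of the propargyl group would follow the same step on both cores. They also leave open whether the agreement survives when the chlorine-bearing chain is replaced, for example by one ending in a carboxylic acid.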